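Low Cytotoxicity Expected After Swapping the Aromatic Substituent

This account rests on a few compounds, and the source may have more. Where it says the series, first, only, none or still open, it means among the compounds named here.

Measured so far:
- compound 1 `COc1ccc(-c2nc(C(C)(C)S(=O)(=O)c3cccc(Cl)c3)nc3ccsc23)cn1` gives > 50000 nM in an ADME assay on cells (Homo sapiens) for cytotoxicity, read by resazurin assay, with a stated time of 5 days (on this read-out lower numbers stand for higher toxicity in this test and higher numbers for lower toxicity in this test), a limit of the assay rather than a number
- compound 2 `COc1ccc(-c2nc(C(C)S(=O)(=O)c3cccc(Cl)c3)nc3ccsc23)cn1` gives > 50000 nM in this assay, also a limit
- compound 3 `O=S(=O)(Cc1nc(-c2ccc(Cl)nc2)c2sccc2n1)c1cccc(Cl)c1` gives 70000 nM in this assay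

For the measured compounds named here, compound 3 is the only compound of the three with an actual number, and it stands at a concentration where cytotoxicity is weak; the other two sit at the limit of > 50000 nM in this assay, at which 2 of the 3 values shown sit.

Compound 4 `COc1ccc(-c2nc(CS(=O)(=O)c3cccc(Cl)c3)nc3ccsc23)cc1` has not been measured. Its difference from compound 3 is 4-methoxyphenyl in place of 6-chloropyridin-3-yl on an aromatic carbon.

Going by the values given here, the one step between measured compounds is a step that the two limits leave unreadable from compound 1 to compound 2, which cannot be read because both ends are limits, and no measured pair mirrors the aromatic swap made here. Among the compounds with values here, every value so far, limit or number, points to weak cytotoxicity, so the expectation for compound 4 in this assay is a step of about a 1.2-fold lower number from compound 3 to compound 4 (0.07 log units; within the scatter), not beyond the scatter. Compound 4 is therefore estimated at 60000 nM, with a likely range from 25000 nM to 150000 nM.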

Compound 4, half-maximal cytotoxic concentration: 69000 nM
Beside the measured number, compound 4's estimate is 1.2-fold (0.06 log units) below it; the range from low to high includes it.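

In this assay, replacing 6-chloropyridin-3-yl with 4-methoxyphenyl on this aromatic carbon gives a 1.0-fold lower number from compound 3 to compound 4 (0.01 log units; within the scatter). For the compounds shown here, this is the first readable comparison at this position, and it shows that exchanging a ring containing nitrogen and carrying chlorine for an all-carbon ring carrying methoxy leaves the read-out within the usual scatter. The only earlier step cannot be read, as both of its ends are limits: the limit of > 50000 nM in this assay, at which 2 of the 4 values shown sit.

The compounds shown leave open whether an amine or a carboxylic acid in place of the aromatic ring on this carbon would also leave the read-out within the scatter. Going by these compounds, what a methyl group on the saturated chain carbon does in this assay also remains open.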